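A few compounds are considered here, and "the series" means these few. Any claim that something is new, unique, unknown or untested is made for them only; others in the source may bear on it.

Working notes on the series. In an ADME assay on Vero cells (Chlorocebus sabaeus) for cytotoxicity, with a stated time of 72 h (a lower number here means a stronger inhibitor, a higher number a weaker inhibitor), compound 1 `CCOC(=O)c1cc(-c2cccc(OCc3cccc(OC(F)(F)F)c3)c2)on1` gives 101000 nM. Compound 2 `CCOC(=O)c1cc(-c2cccc(OCc3cccc(C#N)c3)c2)on1` does not return a number in this assay but only a limit, > 128000 nM. Compound 3 `CCOC(=O)c1cc(-c2cccc(OCc3ccccc3C(F)(F)F)c2)on1` likewise returns only a limit in this assay, > 128000 nM. Compound 2 therefore stands at the weak end of what has been seen here, and the limit of > 128000 nM in this assay, at which 2 of the 3 values shown sit, marks where it sits.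

The change from compound 2 to compound 4 `CCOC(=O)c1cc(-c2cccc(OCc3ccccc3[N+](=O)[O-])c2)on1` is 2-nitrophenyl in place of 3-cyanophenyl on a saturated chain carbon bound to an oxygen on an aromatic ring. Among the measured compounds shown here, the one measured step that touches the same outer ring is an at least 1.2-fold higher number from compound 1 to compound 2 (0.10 log units; that floor lies within the scatter), which carries a number into the limit of this assay. For the measured compounds named here, no measured step involves a nitrophenyl group, so its effect in this assay is unknown. Given that two of the three values sit at the limit, no movement beyond the scatter is expected. The expected step is accordingly a step that the limit leaves unreadable from compound 2 to compound 4. Compound 4 is estimated at 140000 nM in this assay, with a range from 70000 nM to 300000 nM, and most likely only a limit will be reported.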

Compound 4, half-maximal inhibitory concentration: > 128000 nM
Compound 4: no number, only a limit (the forecaster's own chance of this, stated with the estimate: 70%); the middle value lies beyond the limit too.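

In this assay compound 4 returns only a limit, > 128000 nM. Compound 2 and compound 3 also return only limits, so neither step to compound 4 can be read. Whether compound 2, compound 3 and compound 4 differ at all in this assay stays open: the limit of > 128000 nM in this assay, at which 3 of the 4 values shown sit.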